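Benzamido for carbamoyl at the pyrazole carbon: compound 4

A few compounds are considered here, and "the series" means these few. Any claim that something is new, unique, unknown or untested is made for them only; others in the source may bear on it.

The set holds three measured compounds. Compound 1 `Cc1cc(C(=O)O)nn1Cc1cc(Br)ccc1OCc1ccccc1` gives 6.31 nM in an assay on CHO-K1 cells for displacement of a labelled ligand from prostaglandin E2 receptor EP1 subtype (Homo sapiens); a lower number here means a stronger inhibitor, a higher number a weaker inhibitor. Compound 2 `Cc1cc(C(=O)NCc2ccccn2)nn1Cc1cc(Cl)ccc1OCc1ccccc1` gives 25.1 nM in this assay, and compound 3 `Cc1cc(C(N)=O)nn1Cc1cc(Cl)ccc1OCC(C)C` gives 126 nM in this assay. Compound 2 therefore stands second highest of the three numbers; its nearest neighbour is compound 1, whose number is lower by a margin beyond the scatter, and the furthest is compound 3, whose number is higher by a margin also beyond the scatter. Going by the values given here, no two measured compounds differ in one place alone, so no single step in this assay has a known size.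

Compound 4 `Cc1cc(NC(=O)c2ccccc2)nn1Cc1cc(Cl)ccc1OCc1ccccc1` is not yet measured. It differs from compound 2 at the aromatic carbon of the five-membered ring as follows: benzamido in place of ((pyridin-2-yl)methyl)carbamoyl on an aromatic carbon. Both groups carry one double bond outside aromatic rings and one hydrogen-bond donor, so the change in this assay is expected to be modest, leaning toward a higher number. The step is expected to be a 2.0-fold higher number from compound 2 to compound 4 (0.30 log units; within the scatter), within or just beyond the scatter. Compound 4 is estimated to give 50 nM in this assay, with a range from 12 nM to 250 nM.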

Compound 4, half-maximal inhibitory concentration: 15.9 nM
Compound 4: middle estimate off by 3.1-fold (0.50 log units), on the high side; low and high end bracket the measured number.
By their numbers in this assay, from the lowest: compound 1; then compounds 4 and 2 (each within the scatter of the next); then compound 3.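

In this assay, going by these compounds alone, benzamido in place of ((pyridin-2-yl)methyl)carbamoyl on the aromatic carbon next to the ring nitrogen gives a 1.6-fold lower number from compound 2 to compound 4 (0.20 log units; within the scatter), the only step of known size so far. With the rest of the molecule unchanged, this position therefore accepts a group joined to the ring through the amide nitrogen rather than the carbonyl carbon, and an end ring of carbon only rather than one with a hetero atom, with no difference beyond the scatter. The two changes arrive together in one step, and nothing measured accounts for the closeness of the two numbers.

From the compounds shown here alone, compound 1 and compound 3 differ from compound 2 and compound 4 in more than one place, so the steps to them cannot be read, and the part played at this position by the carboxylic acid of compound 1 or the unsubstituted carbamoyl of compound 3 remains unknown. Also open, going by these compounds, is whether a sulfonamide, an amine or a longer chain between the amide and the end ring, placed on the core of compound 4, would keep the number in the same range.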